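Adding a methyl to the piperidine of compound 2

The source may report more compounds than this note shows. Statements on the series, on what has been measured and on what is new or still open speak of the compounds shown alone.

Measured so far in a functional assay on MES-SA/Dx5 cells (Homo sapiens) for inhibition, with a stated time of 72 h; a higher number here means a weaker inhibitor, a lower number a stronger inhibitor
Compound 1 `COCc1cc(CN2CCCC2)c(O)c2ncccc12` gives 1350 nM
Compound 2 `COCc1cc(CN2CCCCC2)c(O)c2ncccc12` gives 912 nM
Compound 3 `CC1CCN(Cc2cc(Cl)c3cccnc3c2O)CC1` gives 260 nM; 257 nM (2 entries)

Compound 2 stands close to compound 1, and the two differ only in the saturated amine ring. That single measured step (a 1.5-fold lower number from compound 1 to compound 2 (0.17 log units; within the scatter)) replaces pyrrolidin-1-yl with piperidin-1-yl.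

From the compounds shown here alone, the next compound is compound 4 `COCc1cc(CN2CCC(C)CC2)c(O)c2ncccc12`, whose value in this assay is still open. The change is methyl in place of hydrogen on a saturated ring carbon and reads as piperidin-1-yl to 4-methylpiperidin-1-yl, with methyl in place of hydrogen on a saturated ring carbon.

Among the compounds with values here, no measured step isolates this methyl, and the step above bears on it only loosely, as a small change at the same amine. Compound 3 carries the same 4-methylpiperidin-1-yl group, and its repeat entries agree (the several entries of compound 3 in this assay, 260 nM; 257 nM (2 entries)). Within the data shown here, its number is lower than that of compound 2, but no single-place step links the two. A small move toward a lower number is therefore expected, not one clearly beyond the scatter.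

The expected step is estimated as follows (a 1.4-fold lower number from compound 2 to compound 4 (0.15 log units; within the scatter)).

For compound 4 the estimated value is 650 nM (expected range 280 nM to 1500 nM).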

Compound 4, half-maximal inhibitory concentration: 575 nM
Compound 4: middle estimate off by 1.1-fold (0.05 log units), on the high side, within the range that was stated.
By their numbers in this assay, from the lowest: compounds 4, 2 and 1 (each within the scatter of the next, the first and the last beyond it).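

In this assay, a methyl on the saturated ring carbon three ring bonds from the ring nitrogen leaves the number within the scatter (a 1.6-fold lower number from compound 2 to compound 4 (0.20 log units; within the scatter)), so this addition alone cannot be told apart from no change. Replacing pyrrolidin-1-yl with 4-methylpiperidin-1-yl does give a modest step beyond the scatter (a 2.3-fold lower number from compound 1 to compound 4 (0.37 log units; beyond the scatter)), which the change to piperidin-1-yl alone did not (a 1.5-fold lower number from compound 1 to compound 2 (0.17 log units; within the scatter)). Two steps that each lie within the scatter therefore add up to a separable difference across these three compounds, and the same 4-methylpiperidin-1-yl group also stands in compound 3, whose entries agree: the several entries of compound 3 in this assay, 260 nM; 257 nM (2 entries).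

From the compounds shown here alone, whether an ethyl or a hydroxyl on this ring carbon would give a step beyond the scatter remains open. So does the effect of a morpholine in place of the piperidine ring.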